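Cyclopentylmethyl on the Piperidine Amine of an Anilide Series

The source may hold more compounds than are shown below. What is called first, only, known or untested is meant among the compounds shown, and "the series" means these compounds.

Measured so far in a functional assay on the whole organism for antagonist activity, with Mus musculus as the target; on this read-out higher numbers stand for an effect only at larger amounts of compound and lower numbers for an effect already at smaller amounts:
- compound 1 `COc1cc(N)c(Cl)cc1NC(=O)C1CCN(CC2CC2)CC1`: > 10 mg/kg, which is a limit of the assay and not a number
- compound 2 `COc1cc(N)c(Cl)cc1NC(=O)C1CCN(CC2CCCCC2)CC1`: 2.9 mg/kg
- compound 3 `COc1cc(N)c(Cl)cc1NC(=O)C1CCN(Cc2ccc(F)cc2)CC1`: 0.6 mg/kg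

Compound 3 stands lowest of the two numbers given, with compound 2 the nearest at a higher number; compound 1 contributes only a limit. Compound 4 `COc1cc(N)c(Cl)cc1NC(=O)C1CCN(CC2CCCC2)CC1` is not yet measured. Its difference from compound 3 is cyclopentyl in place of 4-fluorophenyl on a saturated chain carbon bound to an amine nitrogen in a ring.

For the measured compounds named here, two measured steps bear on this change. Going from cyclohexyl to 4-fluorophenyl at the same place gave a 4.8-fold lower number from compound 2 to compound 3 (0.68 log units; beyond the scatter), and from cyclopropyl to 4-fluorophenyl gave an at least 16-fold lower number from compound 1 to compound 3 (1.22 log units; beyond the scatter). Compound 4 carries cyclopentyl, a saturated ring sized between cyclopropyl and cyclohexyl, so the move away from 4-fluorophenyl is expected to raise the number in this assay by a modest to large amount, with some chance that only a limit is reported. For compound 4 the expected step is a 6.7-fold higher number from compound 3 to compound 4 (0.82 log units; beyond the scatter). Compound 4 is therefore estimated at 4 mg/kg, within a range from 1.5 mg/kg to 12 mg/kg.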

Compound 4, dose for half-maximal effect: > 10 mg/kg
Compound 4 gave a limit, no number (the forecaster's own chance of this, stated with the estimate: 25%); middle value at least 2.5-fold (0.39 log units) from the limit.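

In this assay compound 4 gives > 10 mg/kg, which is a limit of the assay and not a number. Putting cyclopentyl in place of 4-fluorophenyl means an at least 16-fold higher number from compound 3 to compound 4 (1.22 log units; beyond the scatter), and putting it in place of cyclohexyl means an at least 3.4-fold higher number from compound 2 to compound 4 (0.53 log units; beyond the scatter), so among the three saturated rings shown at this place only cyclohexyl gives a number, and a saturated ring as such does not keep the effect. Compound 1 and compound 4 both end at the same limit, so the step that joins them cannot be read: the limit of > 10 mg/kg in this assay, at which 2 of the 4 values shown sit.

The compounds shown leave open whether the fluorine of the 4-fluorophenyl matters, which a plain phenyl would test. They also leave open how a longer chain carrying that ring, such as 2-(4-fluorophenyl)ethyl, would read in this assay.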